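A few compounds are considered here, and "the series" means these few. Any claim that something is new, unique, unknown or untested is made for them only; others in the source may bear on it.

Working notes on the series.

Three compounds of the shared core have numbers in a functional assay on PC-3 cells (Homo sapiens) for cytotoxicity, read by MTT assay, with a stated time of 72 h; a higher number here means a weaker inhibitor, a lower number a stronger inhibitor. Compound 1 `O=C(Nc1ccc(Oc2ccnc3[nH]ccc23)c(F)c1)c1nn(-c2ccc(Cl)cc2)ccc1=O` gives 42500 nM and compound 2 `O=C(Nc1ccc(Oc2ccnc3[nH]ccc23)c(F)c1)c1nn(-c2ccccc2)ccc1=O` gives 38600 nM; the step of a 1.1-fold lower number from compound 1 to compound 2 (0.04 log units; within the scatter) is within the scatter. Compound 3 `O=C(Nc1ccc(Oc2ccnc3[nH]ccc23)c(F)c1)c1nn(-c2ccc(Br)cc2F)ccc1=O` gives 8800 nM, the lowest of the three numbers, and both steps toward it lie beyond the scatter: a 4.8-fold lower number from compound 1 to compound 3 (0.68 log units; beyond the scatter) and a 4.4-fold lower number from compound 2 to compound 3 (0.64 log units; beyond the scatter).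

Compound 4 `O=C(Nc1ccc(Oc2ccnc3[nH]ccc23)c(F)c1)c1nn(-c2ccc(Cl)c(C(F)(F)F)c2)ccc1=O` has not yet been measured. It differs from compound 3 in one place: 4-chloro-3-(trifluoromethyl)phenyl in place of 4-bromo-2-fluorophenyl on an aromatic nitrogen. The measured steps that bear on this change are those that alter the ring on the same aromatic nitrogen, namely a 4.8-fold lower number from compound 1 to compound 3 (0.68 log units; beyond the scatter) and a 4.4-fold lower number from compound 2 to compound 3 (0.64 log units; beyond the scatter), each modest, and a 1.1-fold lower number from compound 1 to compound 2 (0.04 log units; within the scatter), which is within the scatter. The data give no step in which a ring of this kind leaves and another substituted ring enters, so the direction of the change from compound 3 is not fixed by the numbers shown. Compound 4 is therefore expected to stay near compound 3, with a step of about a 1.7-fold higher number from compound 3 to compound 4 (0.23 log units; within the scatter) in this assay that may fall within the scatter. The estimate for compound 4 is 15000 nM, with a range from 4000 nM to 50000 nM.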

Compound 4, half-maximal inhibitory concentration: 5500 nM
For compound 4 the middle estimate is 2.7-fold (0.44 log units) above the measured one; low and high end bracket the measured number.
By their numbers in this assay, from the lowest: compounds 4 and 3 (each within the scatter of the next); then compounds 2 and 1 (each within the scatter of the next).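

Within this assay, a 7.7-fold lower number from compound 1 to compound 4 (0.89 log units; beyond the scatter) shows that adding trifluoromethyl to the 4-chlorophenyl ring on the aromatic nitrogen shifts the number beyond the scatter, whereas the earlier step of a 1.1-fold lower number from compound 1 to compound 2 (0.04 log units; within the scatter), which concerns only the chloro group, did not; a 7.0-fold lower number from compound 2 to compound 4 (0.85 log units; beyond the scatter) places compound 4 clearly apart from the unsubstituted phenyl as well. Among these compounds, with a 1.6-fold lower number from compound 3 to compound 4 (0.20 log units; within the scatter), two differently substituted rings, 4-bromo-2-fluorophenyl and 4-chloro-3-(trifluoromethyl)phenyl, cannot be told apart at this position, so among the four compounds the two rings with a second substituent both stand apart from phenyl and 4-chlorophenyl, and no compound goes against this. No measurement in hand accounts for these steps.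

The compounds shown leave open whether trifluoromethyl alone, without the chloro group, would give the same shift, and whether the two halogens of compound 3 each contribute to its number. They also leave open how a ring carrying an amine or a carboxylic acid, or a saturated cyclohexyl ring, would behave on this nitrogen.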